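A Dimethylamino Swap on the Sulfonyl Sulfur

A few compounds are considered here, and "the series" means these few. Any claim that something is new, unique, unknown or untested is made for them only; others in the source may bear on it.

In an ADME assay on microsomes (Homo sapiens) for metabolic stability (on this read-out lower numbers stand for slow clearance and higher numbers for fast clearance), compound 3 `Cc1cc(C(F)(F)F)c2cccc(OCc3c(Cl)ccc(S(=O)(=O)N4CCC[C@H]4CO)c3Cl)c2n1` gives 250 mL/min/kg, within the scatter of compound 1 `CCc1cc(C(F)(F)F)c2cccc(OCc3c(Cl)ccc(S(=O)(=O)N4CCC[C@H]4C(=O)NC)c3Cl)c2n1` at 300 mL/min/kg. Compound 2 `Cc1cc(C(F)(F)F)c2cccc(OCc3c(Cl)ccc(S(=O)(=O)N4CCC[C@H]4C(=O)O)c3Cl)c2n1`, at 8.33 mL/min/kg, lies far lower than both. Compound 4 `Cc1cc(C(F)(F)F)c2cccc(OCc3c(Cl)ccc(S(=O)(=O)N4CC[C@@H](N(C)C)C4)c3Cl)c2n1` differs from compound 3 by 3-(dimethylamino)pyrrolidin-1-yl in place of 2-(hydroxymethyl)pyrrolidin-1-yl on a sulfonyl sulfur. Among the measured compounds shown here, the only measured step, a 30-fold higher number from compound 2 to compound 3 (1.48 log units; beyond the scatter), is large, but it exchanges a carboxy group for hydroxymethyl and does not test this swap on the sulfonyl sulfur. Compound 4 has no carboxy group, and neither does compound 3 at 250 mL/min/kg. No change beyond the scatter is therefore expected, and the expected step is a 1.4-fold lower number from compound 3 to compound 4 (0.14 log units; within the scatter). Compound 4 is estimated at 180 mL/min/kg, with an expected range of 60 mL/min/kg to 400 mL/min/kg.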

Compound 4, clearance: 167 mL/min/kg
For compound 4 the middle estimate is 1.1-fold (0.03 log units) above the measured one; measured number inside the range.
By their numbers in this assay, from the lowest: compound 2; then compounds 4, 3 and 1 (each within the scatter of the next).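

On the sulfonyl sulfur, 3-(dimethylamino)pyrrolidin-1-yl in place of 2-(hydroxymethyl)pyrrolidin-1-yl gives a 1.5-fold lower number from compound 3 to compound 4 (0.18 log units; within the scatter) in this assay so two different groups without a carboxy group cannot be told apart at this position. With the same group in place of 2-carboxypyrrolidin-1-yl the step is a 20-fold higher number from compound 2 to compound 4 (1.30 log units; beyond the scatter) and among these compounds only compound 2, the one carrying a carboxy group, stands low. No measurement at hand bears on why the numbers fall this way. As far as these compounds go, whether a morpholine or an open-chain amine on the sulfonyl sulfur would also stand with compound 3 and compound 4 remains open.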